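From isopropylcarbonyl to vinylcarbonyl on the shared core

The compounds below may be only part of what the source reports. "The series", "measured", "known", "first", "only" and "open" are said of these compounds alone.

In an ADME assay on L02 cells (Homo sapiens) for cytotoxicity, read by MTT assay (on this read-out higher numbers stand for weaker inhibition and lower numbers for stronger inhibition), compound 3 `COc1ccc(/C=C/C(=O)c2ccc(OC)c3c2OC(C)(C)C=C3)cc1OC(=O)C(C)C` gives > 10000 nM, and this is a limit. Compound 1 `C=CCOc1cc(/C=C/C(=O)c2ccc(OC)c3c2OC(C)(C)C=C3)ccc1OC` gives > 20000 nM, also a limit. Compound 2 `COc1ccc(/C=C/C(=O)c2ccc(OC)c3c2OC(C)(C)C=C3)cc1OCCCN(C)C` gives a number, 8600 nM. Compound 4 `C=CC(=O)Oc1cc(/C=C/C(=O)c2ccc(OC)c3c2OC(C)(C)C=C3)ccc1OC` carries vinyl in place of isopropyl on a carbonyl carbon. Going by the values given here, no measured step makes this exchange. The nearest evidence is weak: the data show an at least 1.1-fold higher number from compound 2 to compound 3 (0.06 log units; that floor lies within the scatter), and a step that the two limits leave unreadable from compound 1 to compound 3. Among the compounds with values here, the one clear change, an at least 2.3-fold lower number from compound 1 to compound 2 (0.36 log units; beyond the scatter), concerns a dimethylamino chain that compound 4 lacks. No shift beyond the scatter is therefore expected, and the expected step is a step that the limit leaves unreadable from compound 3 to compound 4. For compound 4 the estimated value is 12000 nM, with an expected range of 5000 nM to 30000 nM.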

Compound 4, half-maximal inhibitory concentration: > 10000 nM
Compound 4 gave a limit, no number (the forecaster's own chance of this, stated with the estimate: 60%); the middle value does not contradict the limit.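

In this assay compound 4 gives > 10000 nM, which is a limit, so vinyl on this carbonyl carbon yields no number, just as isopropyl did. Compound 3 and compound 4 end at the same limit, and the steps from compound 3 and from compound 1 to compound 4 cannot be read: the limit of > 10000 nM in this assay, at which 2 of the 4 values shown sit. The data show an at least 1.1-fold higher number from compound 2 to compound 4 (0.06 log units; that floor lies within the scatter), so the vinylcarbonyl group is not separated from the 3-(dimethylamino)propyl chain. From the compounds shown here alone, whether vinyl and isopropyl differ at all stays open. Going by these compounds, how a longer chain ending in a carboxylic acid would read on this oxygen also stays open.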